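The source may hold more compounds than are shown below. What is called first, only, known or untested is meant among the compounds shown, and "the series" means these compounds.

Measured in a functional assay on U-87MG ATCC cells for cytotoxicity against U-87 MG (Homo sapiens), read by MTT assay, with a stated time of 48 h; on this read-out lower numbers stand for stronger inhibition and higher numbers for weaker inhibition:

- compound 1 `O=C(O[C@H]1C[C@H](n2cc(F)c(=O)[nH]c2=O)O[C@@H]1COP(=O)(O)Oc1ccc2ncccc2c1)c1ccccc1`: 880 nM
- compound 2 `O=C(O[C@H]1C[C@H](n2cc(F)c(=O)[nH]c2=O)O[C@@H]1COP(=O)([O-])Oc1ccc[n+](Cc2ccccc2)c1)c1ccccc1`: 660 nM

Compound 1 has the higher of these two numbers, but compound 2 lies within the usual scatter of it, so the two cannot be told apart in this test. Both compounds carry a benzoyl group. Compound 3 `O=c1[nH]c(=O)n([C@H]2C[C@H](O)[C@@H](COP(=O)(O)Oc3ccc4ncccc4c3)O2)cc1F` is the unmeasured partner of compound 1, and the change between them is hydrogen in place of benzoyl on an oxygen on a saturated carbon. Put simply, it is benzoyloxy to hydroxy, with hydrogen in place of benzoyl on an oxygen on a saturated carbon. Among the measured compounds shown here, no measured pair shows this change, so its size remains open and any forecast must stay broad. No step beyond the scatter is expected in this assay, and the estimated shift is a 1.1-fold lower number from compound 1 to compound 3 (0.04 log units; within the scatter). For compound 3 the expected value is 800 nM, with an estimated range of 150 nM to 4000 nM.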

Compound 3, half-maximal inhibitory concentration: 10700 nM
For compound 3 the middle estimate is 13-fold (1.13 log units) below the measured one, and the stated range ends below it.
By their numbers in this assay, from the lowest: compounds 2 and 1 (each within the scatter of the next); then compound 3.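

Swapping benzoyl for hydrogen on this oxygen on a saturated carbon is a large change in this assay, giving a 12-fold higher number from compound 1 to compound 3 (1.08 log units; beyond the scatter). Compound 1 and compound 2 both carry the benzoyl group, so they could not show what its loss does; this pair shows that, on the core of compound 1, the benzoyloxy form gives much stronger inhibition than the hydroxy form. No data shown here explain the size of this step.

On these data alone, it remains open which part of the benzoyl group matters: an acetyl group or a benzyl ether on the same oxygen would separate the carbonyl from the aromatic ring. As far as these compounds go, whether a step of this size also holds on the core of compound 2 remains open too.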